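Sulfamate series: aliphatic amine replaces pyridylmethyl amine

A few compounds are considered here, and "the series" means these few. Any claim that something is new, unique, unknown or untested is made for them only; others in the source may bear on it.

Of the compounds shown here, three have been measured in an assay on HEK293 cells for inhibition of Steryl-sulfatase (Homo sapiens), tested at 1 uM; on this read-out lower numbers stand for a weaker effect and higher numbers for a stronger effect at the one concentration tested. Compound 1 `NS(=O)(=O)Oc1ccc2c(c1)CN(C(=O)c1cccc(N3CCC(N4CCCCC4)CC3)c1)CC2` gives 8%. Compound 2 `CCN(Cc1ccccc1)c1cccc(C(=O)N2CCc3ccc(OS(N)(=O)=O)cc3C2)c1` gives 69%. Compound 3 `CCN(Cc1ccccn1)c1ccc(C(=O)N2CCc3ccc(OS(N)(=O)=O)cc3C2)cc1` gives 87.7%, the highest of the three numbers; its nearest neighbour is compound 2, lower by a margin beyond the scatter, and the furthest is compound 1, lower by a much larger margin. The two higher numbers belong to the compounds bearing an amino group with an ethyl and an aromatic methyl substituent, while compound 1, carrying a non-aromatic saturated amine, sits far below.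

Compound 4 `CN(CCN1CCCCC1)c1ccc(C(=O)N2CCc3ccc(OS(N)(=O)=O)cc3C2)cc1` has not yet been measured. It differs from compound 3 in one place: methyl(2-(piperidin-1-yl)ethyl)amino in place of ethyl((pyridin-2-yl)methyl)amino on an aromatic carbon. The entering group keeps the same count of heavy atoms and acceptors but exchanges the aromatic ring for a non-aromatic one.

Among the measured compounds shown here, no step between measured compounds can be calculated here, so the size of the change is a matter of expectation only. Because compound 1 with its non-aromatic amine gives 8%, a downward step is expected in this assay, a number 42.7 percentage points lower from compound 3 to compound 4 (beyond the scatter), beyond the scatter. Compound 4 is estimated to give 45%, with a range from 10% to 80%.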

Compound 4, a percentage reported as inhibition, at one concentration (the size of the read-out at that concentration, not a potency): 26.8%
Compound 4: middle estimate off by 18.2 percentage points, on the high side; measured number inside the range.
By their numbers in this assay, from the lowest: compound 1; then compound 4; then compound 2; then compound 3.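

Among the compounds shown here, at this position, on an aromatic carbon para to a large group, methyl(2-(piperidin-1-yl)ethyl)amino in place of ethyl((pyridin-2-yl)methyl)amino gives a number 60.9 percentage points lower from compound 3 to compound 4 (beyond the scatter) in this assay, and this is the only single-place comparison so far. The leaving and entering groups have the same computed counts of heavy atoms, carbon, nitrogen, hydrogen-bond donors and acceptors and the same net charge, so these counts do not separate them, and a large step can arise at this position without any change in them. No measurement here accounts for the step, and the part of the exchange that carries it remains unassigned.

The exchange changes several things together: a six-membered aromatic ring becomes a non-aromatic one, the link to the ring changes and ethyl on the amino nitrogen becomes methyl, so the compounds shown cannot assign the step to any one of them. As far as these compounds go, it remains open whether a 2-(pyridin-2-yl)ethyl group or a 2-(morpholin-4-yl)ethyl group at this position would read closer to compound 3 or to compound 4.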